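Dimethoxymethyl in place of cyclopentyl on the side chain

A few compounds are considered here, and "the series" means these few. Any claim that something is new, unique, unknown or untested is made for them only; others in the source may bear on it.

For the measured compounds named here, in a functional assay on U-87MG ATCC cells for antiproliferative activity against U-87 MG (Homo sapiens), with a stated time of 5 days (a higher number here means that more compound is needed for the effect, a lower number that less compound is needed), compound 2 `Nc1nc2cc(-c3nn(CC4CCCC4)c4ncnc(N)c34)ccc2o1` gives 13 nM as the lower of the two numbers so far, and compound 1 `Nc1nc2cc(-c3nn(CC4CCCO4)c4ncnc(N)c34)ccc2o1` gives 100 nM as the higher. Compound 3 `COC(Cn1nc(-c2ccc3oc(N)nc3c2)c2c(N)ncnc21)OC` carries dimethoxymethyl in place of cyclopentyl on a saturated chain carbon bound to an aromatic nitrogen and thus loses the ring. Going by the values given here, one measured step bears on this: a 7.7-fold lower number from compound 1 to compound 2 (0.89 log units; beyond the scatter) for cyclopentyl in place of oxolan-2-yl. That step is modest and beyond the scatter. Read in reverse, it points to a higher number when cyclopentyl gives way to an oxygen-bearing group, although no open-chain group has been measured. A step of similar size is therefore expected in this assay, and the expected step is a 6.9-fold higher number from compound 2 to compound 3 (0.84 log units; beyond the scatter) overall. Compound 3 is estimated at 90 nM (expected range 25 nM to 300 nM).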

Compound 3, half-maximal effective concentration: 100 nM
Beside the measured number, compound 3's estimate is 1.1-fold (0.05 log units) below it; the measured number falls inside the stated range.
By their numbers in this assay, from the lowest: compound 2; then compounds 1 and 3 (each within the scatter of the next).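

In this assay the open-chain acetal behaves like the cyclic ether, not like the carbocycle: dimethoxymethyl gives a 7.7-fold higher number from compound 2 to compound 3 (0.89 log units; beyond the scatter) and, set against oxolan-2-yl, gives no change at the digits printed from compound 1 to compound 3 (within the scatter). On a saturated chain carbon bound to an aromatic nitrogen, a ring is therefore not needed to reach the number of compound 1, and among these three compounds only cyclopentyl, in compound 2, stands apart with the lowest number. Nothing on hand explains why the two oxygen-bearing groups sit together or why cyclopentyl differs.

Open, going by these compounds, is whether an open-chain all-carbon group such as pentan-3-yl would fall with compound 2 or with compounds 1 and 3, which would separate the loss of the ring from the entry of oxygen. Also open, on these data alone, is how an amine such as dimethylamino or a carboxylic acid would read on the same carbon.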